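The source may hold more compounds than are shown below. What is called first, only, known or untested is meant among the compounds shown, and "the series" means these compounds.

Measured in a functional assay on HepG2 cells (Homo sapiens) for cytotoxicity, with a stated time of 24 h; a higher number here means a weaker inhibitor, a lower number a stronger inhibitor:
- compound 1 `COc1cc(Cl)ccc1C(=O)Nc1cc(Cl)c(Cl)cc1O`: 11500 nM
- compound 2 `COc1ccc(Cl)cc1C(=O)Nc1ccc(Cl)cc1O`: 51300 nM
- compound 3 `COc1ccc(Cl)cc1C(=O)Nc1ccc(Br)cc1O`: 7980 nM

Compound 3, at 7980 nM, lies within the scatter of compound 1, at 11500 nM. These two values are the lowest of the three, and compound 2 stands clearly higher at 51300 nM.

The next compound to consider is compound 4 `COc1ccc(Cl)cc1C(=O)Nc1ccc(C(F)(F)F)cc1O`. It carries trifluoromethyl in place of bromo on an aromatic carbon, meta to a hydroxy group and para to a large group (trifluoromethyl in place of bromo on an aromatic carbon).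

Going by the values given here, only one measured step bears on this change. It is a 6.4-fold lower number from compound 2 to compound 3 (0.81 log units; beyond the scatter), a modest step beyond the scatter, with bromo in place of chloro at the same place. That step shows that this assay can respond to a swap at this carbon. It is a single halogen exchange, however, and gives no direction for trifluoromethyl. Among the compounds with values here, compound 1 differs from the others in more than one place and adds no step.

With so little to go on, no shift beyond the scatter is expected, and the estimated change is a 1.1-fold lower number from compound 3 to compound 4 (0.06 log units; within the scatter). For compound 4 the expected value is 7000 nM, with an estimated range of 2500 nM to 25000 nM.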

Compound 4, half-maximal inhibitory concentration: 4910 nM
Estimate against measurement, compound 4: 1.4-fold (0.15 log units) above; measured number inside the range.
By their numbers in this assay, from the lowest: compounds 4, 3 and 1 (each within the scatter of the next, the first and the last beyond it); then compound 2.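

In this assay this carbon now carries three different groups, and trifluoromethyl cannot be told from bromo there (a 1.6-fold lower number from compound 3 to compound 4 (0.21 log units; within the scatter)), even though it enters with more heavy atoms than the single bromine it replaces. Set against chloro, the same group gives a large step (a 10-fold lower number from compound 2 to compound 4 (1.02 log units; beyond the scatter)), so compounds 3 and 4 both stand clearly apart from compound 2, and among these three compounds it is the chloro compound that is the odd one out, not either of the other two groups. Nothing measured alongside these numbers speaks to why chloro stands apart at this carbon.

The compounds shown leave open how an amine, a carboxylic acid or a plain hydrogen would read at this carbon, as bromo and trifluoromethyl both enter or leave with no hydrogen-bond donors or acceptors and no net charge. Also open, as far as these compounds go, is whether the step away from chloro carries over to the core of compound 1, which differs from the others in more than one place and so gives no comparison here.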